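Adding a Hexyloxy Chain at the Limit of Detection

This account rests on a few compounds, and the source may have more. Where it says the series, first, only, none or still open, it means among the compounds named here.

In an ADME assay on RAW264.7 cells (Mus musculus) for cytotoxicity, read by MTT assay, with a stated time of 24 h, in the presence of a further agent that is not named here (on this read-out higher numbers stand for weaker inhibition and lower numbers for stronger inhibition), compound 3 `COc1ccc(C(O)C2OC(=O)c3c(OC)cc(OC)cc32)cc1` gives > 40000 nM as a limit and not a number. Compound 1 `Cc1noc(CC2OC(=O)c3ccccc32)n1` gives > 40000 nM as a limit as well. Compound 2 `O=C1OC(Cc2nc(Cc3ccccc3)no2)c2ccccc21` likewise gives > 40000 nM as a limit. The picture so far is therefore the limit of > 40000 nM in this assay, at which 3 of the 3 values shown sit, and nothing finer.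

Compound 4 `CCCCCCOc1ccc(C(O)C2OC(=O)c3c(OC)cc(OC)cc32)cc1` differs from compound 3 at one place. The difference is pentyl in place of hydrogen on a saturated chain carbon bound to an oxygen on an aromatic ring and turns methoxy into hexyloxy, with pentyl in place of hydrogen on a saturated chain carbon bound to an oxygen on an aromatic ring.

Among the measured compounds shown here, the only measured step is a step that the two limits leave unreadable from compound 1 to compound 2 and it concerns a different place, so it offers no size to carry over. Only a small step toward stronger inhibition, or none beyond the scatter, is thus expected in this assay for this change. The estimated step is an at least 1.1-fold lower number from compound 3 to compound 4 (0.05 log units; that floor lies within the scatter) in this expectation. Compound 4 is expected at about 35000 nM (12000 nM to 60000 nM) in this assay, quite possibly again reported only as a limit.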

Compound 4, half-maximal inhibitory concentration: > 40000 nM
Compound 4: only a limit was reported; the forecaster's own chance of this, stated with the estimate: 65%; at least 1.1-fold (0.05 log units) between middle value and limit.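

In this assay compound 4 gives > 40000 nM, a limit and not a number. Among the compounds shown here, compound 3 also stands at a limit, so no step between compound 3 and compound 4 can be read. The compounds shown leave open how far methoxy to hexyloxy shifts inhibition, if at all, with every value at one limit: the limit of > 40000 nM in this assay, at which 4 of the 4 values shown sit.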